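Removing Two Bromines from the Weakest Hydrazone Analogue

This account rests on a few compounds, and the source may have more. Where it says the series, first, only, none or still open, it means among the compounds named here.

The series shares one core carrying an acylhydrazone whose aryl group varies. In a functional assay on MKN-45 cells (Homo sapiens) for cytotoxicity, read by MTT assay, with a stated time of 72 h (a lower number here means a stronger inhibitor, a higher number a weaker inhibitor), compound 1 `COc1ccc(OC)c(/C=N/NC(=O)Nc2ccc(Oc3ccnc(-c4nncn4CCN(C)C)c3)c(F)c2)c1` gives 1510 nM, compound 2 `CN(C)CCn1cnnc1-c1cc(Oc2ccc(NC(=O)N/N=C/c3cccc(Br)c3)cc2F)ccn1` gives 450 nM, and compound 3 `CN(C)CCn1cnnc1-c1cc(Oc2ccc(NC(=O)N/N=C/c3cc(Br)c(O)c(Br)c3)cc2F)ccn1` gives 4320 nM. Compound 3 thus stands as the weakest of the three in this assay: the step of a 2.9-fold higher number from compound 1 to compound 3 (0.46 log units; beyond the scatter) and the step of a 9.6-fold higher number from compound 2 to compound 3 (0.98 log units; beyond the scatter) both run against it, while a 3.4-fold lower number from compound 1 to compound 2 (0.53 log units; beyond the scatter) marks compound 2 as the strongest.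

Compound 4 `CN(C)CCn1cnnc1-c1cc(Oc2ccc(NC(=O)N/N=C/c3ccc(O)cc3)cc2F)ccn1` differs from compound 3 by 4-hydroxyphenyl in place of 3,5-dibromo-4-hydroxyphenyl on a carbon with a double bond to nitrogen. For the measured compounds named here, no measured step strips bromines while keeping the hydroxyl, so the closest guide is a 9.6-fold higher number from compound 2 to compound 3 (0.98 log units; beyond the scatter), where the 3,5-dibromo-4-hydroxyphenyl group gave the weakest number, and compound 2 with a single bromine and no hydroxyl gave the strongest. Loss of both bromines is therefore expected to move compound 4 back toward the middle of the range, a step of a 2.9-fold lower number from compound 3 to compound 4 (0.46 log units; beyond the scatter) in this assay. Compound 4 is estimated at 1500 nM, within 400 nM to 6000 nM.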

Compound 4, half-maximal inhibitory concentration: 820 nM
Estimate against measurement, compound 4: 1.8-fold (0.26 log units) above; the measured number falls inside the stated range.
By their numbers in this assay, from the lowest: compounds 2, 4 and 1 (each within the scatter of the next, the first and the last beyond it); then compound 3.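

In this assay the step of a 5.3-fold lower number from compound 3 to compound 4 (0.72 log units; beyond the scatter) shows that the weak number of compound 3 goes with the two bromines, since the hydroxyl stays in place while the number drops. The steps of a 1.8-fold higher number from compound 2 to compound 4 (0.26 log units; within the scatter) and of a 1.8-fold lower number from compound 1 to compound 4 (0.27 log units; within the scatter) both lie within the scatter, so at this carbon with a double bond to nitrogen the 4-hydroxyphenyl group cannot be told apart from either 3-bromophenyl or 2,5-dimethoxyphenyl. Nothing available gives a reason for the size of the bromine step.

The compounds shown leave open whether a single bromine on the 4-hydroxyphenyl group would give a number closer to that of compound 3 or that of compound 4. They also leave open whether an amine or a carboxylic acid in place of the hydroxyl would stay within the same range.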